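A few compounds are considered here, and "the series" means these few. Any claim that something is new, unique, unknown or untested is made for them only; others in the source may bear on it.

Measured compounds in an ADME assay on liver for metabolic stability, with Liver microsome (Homo sapiens) as the target, using microsomes; on this read-out higher numbers stand for fast clearance and lower numbers for slow clearance:
Compound 1 `O=C(Nc1cc(-c2ccccn2)n[nH]1)N1CCC(Oc2ccccn2)CC1` gives a limit of the assay, < 11.9 mL.min-1.g-1.
Compound 2 `N#Cc1ccc(OC2CCN(C(=O)Nc3cc(-c4ccccn4)n[nH]3)CC2)cc1` gives 14.7 mL.min-1.g-1.
Compound 3 `O=C(Nc1cc(-c2ccccn2)n[nH]1)N1CCN(c2ccc(F)cc2)CC1` gives 30.8 mL.min-1.g-1.

Compound 2 holds the lower of the two numbers, and the gap to compound 3 is beyond the usual scatter of this assay. Going by the values given here, the one step measured at the same position, an at least 1.2-fold higher number from compound 1 to compound 2 (0.09 log units; that floor lies within the scatter), runs from compound 1, whose result is only a limit (the limit of < 11.9 mL.min-1.g-1 in this assay, at which 1 of the 3 values shown sits), so its true size is not known.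

Compound 4 `O=C(Nc1cc(-c2ccccn2)n[nH]1)N1CCC(c2cccc(F)c2)CC1` differs from compound 2 as follows: 3-fluorophenyl in place of 4-cyanophenoxy on a saturated ring carbon. Among the compounds with values here, no measured step changes the group on that saturated ring carbon in this way, so the step of an at least 1.2-fold higher number from compound 1 to compound 2 (0.09 log units; that floor lies within the scatter) is the only guide, and it is small. A modest rise in this assay is therefore expected, with wide uncertainty, a 1.4-fold higher number from compound 2 to compound 4 (0.13 log units; within the scatter). Compound 4 is estimated at 20 mL.min-1.g-1, between 8 mL.min-1.g-1 and 45 mL.min-1.g-1.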

Compound 4, intrinsic clearance in microsomes: 25.3 mL.min-1.g-1
Beside the measured number, compound 4's estimate is 1.3-fold (0.10 log units) below it; measured number inside the range.
By their numbers in this assay, from the lowest: compounds 2, 4 and 3 (each within the scatter of the next, the first and the last beyond it). At a limit, below all of these: compound 1.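

In this assay, exchanging 4-cyanophenoxy for 3-fluorophenyl on the saturated ring carbon gives a 1.7-fold higher number from compound 2 to compound 4 (0.24 log units; within the scatter), so this larger change, which removes the oxygen link and the nitrile together, stays within the usual scatter. On the same carbon, 3-fluorophenyl in place of (pyridin-2-yl)oxy gives an at least 2.1-fold higher number from compound 1 to compound 4 (0.32 log units; beyond the scatter), the first step at this position to pass beyond the scatter. (Compound 1 holds only a limit, so the true size of that step is not known: the limit of < 11.9 mL.min-1.g-1 in this assay, at which 1 of the 4 values shown sits)

The compounds shown do not separate the two parts of the change, which a 4-cyanophenyl joined directly to the ring carbon or a 3-fluorophenoxy joined through oxygen would address. They also leave open how the read-out responds when that carbon carries an amine or a carboxylic acid.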